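A few compounds are considered here, and "the series" means these few. Any claim that something is new, unique, unknown or untested is made for them only; others in the source may bear on it.

The three measured compounds, each with its half-maximal inhibitory concentration in a functional assay on KB cells (Homo sapiens) for antiproliferative activity, read by MTT assay, with a stated time of 72 h; on this read-out lower numbers stand for stronger inhibition and higher numbers for weaker inhibition:

compound 1 `CN(C(=O)c1ccc(Cl)cc1)c1ccc2[nH]c(-c3n[nH]c4ccccc34)cc2n1` gives 630 nM
compound 2 `Cc1ccc(S(=O)(=O)N(C)c2ccc3[nH]c(-c4n[nH]c5ccccc45)cc3n2)cc1` gives 9500 nM
compound 3 `COc1ccc(S(=O)(=O)N(C)c2ccc3[nH]c(-c4n[nH]c5ccccc45)cc3n2)cc1` gives 22100 nM

Compound 3 stands highest of these three numbers in this assay, that is, it is the weakest inhibitor of the set. Its nearest neighbour is compound 2, separated by a 2.3-fold higher number from compound 2 to compound 3 (0.37 log units; beyond the scatter); compound 1 lies much further away, and the values of compound 1 and compound 3 show a wide gap between them. The larger part of that gap comes from a 15-fold higher number from compound 1 to compound 2 (1.18 log units; beyond the scatter).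

Compound 4 `COc1ccc(S(=O)(=O)N(C)c2ccc3[nH]c(-c4n[nH]c5ccccc45)cc3n2)c(OC)c1` differs from compound 3 in one place: methoxy in place of hydrogen on an aromatic carbon. Among the compounds with values here, no measured step repeats this change. The step from compound 2 to compound 3, which also altered the substituent on the same six-membered ring, was modest; the step from compound 1 to compound 2 replaced the whole carbonyl-to-sulfonyl linkage and does not bear on a second methoxy. Within the data shown here, with only that weak guide, the second methoxy is expected to leave the number roughly where compound 3 stands, with at most a small further rise.

Compound 4 is therefore expected to give 26000 nM in this assay, within a range of 10000 nM to 65000 nM, which means an expected step of a 1.2-fold higher number from compound 3 to compound 4 (0.07 log units; within the scatter).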

Compound 4, half-maximal inhibitory concentration: 10200 nM
The estimate for compound 4 lay 2.5-fold (0.41 log units) above the measured number; measured number inside the range.
By their numbers in this assay, from the lowest: compound 1; then compounds 2 and 4 (each within the scatter of the next); then compound 3.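

In this assay, a methoxy on the aromatic carbon ortho to a large group, which turns 4-methoxyphenyl into 2,4-dimethoxyphenyl, gives a 2.2-fold lower number from compound 3 to compound 4 (0.34 log units; beyond the scatter) and so moves the number down, a direction that the earlier step from methyl to methoxy, a 2.3-fold higher number from compound 2 to compound 3 (0.37 log units; beyond the scatter), did not show. This is the first compound shown with a substituent at this position, and it shows that the position accepts a methoxy without any loss of activity against compound 3. The 2,4-dimethoxyphenyl of compound 4 and the 4-methylphenyl of compound 2 cannot be told apart, with a 1.1-fold higher number from compound 2 to compound 4 (0.03 log units; within the scatter), and nothing available explains why the added methoxy lowers the number.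

From the compounds shown here alone, it remains open whether the fall belongs to methoxy itself or would also follow from a smaller or different group on that carbon, such as a methyl, a chlorine or an amine, and whether a lone 2-methoxy would behave the same way without the 4-methoxy. Going by these compounds, it is equally open whether the same methoxy would lower the number in the carbonyl-linked series of compound 1.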